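Swapping chloro for bromo on a weak cytotoxic series

A few compounds are considered here, and "the series" means these few. Any claim that something is new, unique, unknown or untested is made for them only; others in the source may bear on it.

Three close relatives share one core. Compound 1 `CC(C)n1c(/C=C2/C(=O)Nc3ccccc32)nc2ccccc21` carries hydrogen at the position in question; in a functional assay on MCF7 cells (Homo sapiens) for cytotoxicity, read by MTT assay, with a stated time of 48 h (a higher number here means a weaker inhibitor, a lower number a stronger inhibitor), compound 1 gives 39500 nM. Compound 3 `CC(C)n1c(/C=C2/C(=O)Nc3ccc(Cl)cc32)nc2ccccc21` carries chloro there, and in this assay compound 3 gives 24000 nM. Compound 2 `CCn1c(/C=C2/C(=O)Nc3ccc(Br)cc32)nc2ccccc21` also carries bromo at that carbon but a shorter chain on the nitrogen, and in this assay compound 2 gives "not determined" (no result reported), so no number was reported for it.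

Compound 3 has the lowest of the two numbers available, with compound 1 nearest; the step of a 1.6-fold lower number from compound 1 to compound 3 (0.22 log units; within the scatter) is within the scatter, so the two cannot be ranked. Compound 4 `CC(C)n1c(/C=C2/C(=O)Nc3ccc(Br)cc32)nc2ccccc21` differs from compound 3 by one change: bromo in place of chloro on an aromatic carbon.

Within the data shown here, no measured step covers a swap of one halogen for another; the only measured step, chloro in place of hydrogen from compound 1 to compound 3, stayed within the scatter. With so little to go on, a step from compound 3 to compound 4 of a 1.1-fold lower number from compound 3 to compound 4 (0.04 log units; within the scatter) is expected, meaning no change beyond the scatter. Compound 4 is therefore estimated at 22000 nM in this assay, with a range from 10000 nM to 50000 nM.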

Compound 4, half-maximal inhibitory concentration: 14900 nM
Compound 4: the middle estimate sits 1.5-fold (0.17 log units) above what was measured; low and high end bracket the measured number.
By their numbers in this assay, from the lowest: compounds 4, 3 and 1 (each within the scatter of the next, the first and the last beyond it).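

In this assay, this carbon on the six-membered aromatic ring now shows a step beyond the scatter: bromo in place of hydrogen gives a 2.7-fold lower number from compound 1 to compound 4 (0.42 log units; beyond the scatter), a modest shift towards stronger inhibition, whereas chloro in place of hydrogen stayed within the scatter. Bromo in place of chloro gives a 1.6-fold lower number from compound 3 to compound 4 (0.21 log units; within the scatter), so the two halogens cannot be ranked against each other, even though only the bromo compound separates clearly from the hydrogen compound. No accompanying data show what lies behind this shift, so the numbers record the size of the change and give no cause for it.

The compounds shown leave open whether a group other than a halogen at this carbon, such as an amine or a carboxylic acid, would shift the number as far as bromo does, or further. They also leave open whether the step from hydrogen to bromo would keep its size with a longer chain on the nitrogen of the shared core.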